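The source may hold more compounds than are shown below. What is called first, only, known or untested is meant among the compounds shown, and "the series" means these compounds.

The series rests on a shared core, shown for compound 1 as `C=C1C[C@]23C[C@@]1(O)CC[C@H]2c1cc2c(C(=O)O)coc2c(C)c1[C@@H]3C(=O)O`, carried also by compound 2 as `C=C1C[C@]23C[C@@]1(O)CC[C@H]2c1cc(Br)c(O/C=C/C(=O)OC)c(C)c1[C@@H]3C(=O)OC` and by compound 3 as `C=C1C[C@]23C[C@@]1(O)CC[C@H]2c1ccc(O/C=C/C(=O)OC)c(C)c1[C@@H]3C(=O)OC`. In a functional assay on NCI-H446 cells (Homo sapiens) for cytotoxicity, read by luminescence and CellTiter-Glo, with a stated time of 24 h (a lower number here means a stronger inhibitor, a higher number a weaker inhibitor), compound 1 gives > 10000 nM, which is a limit of the assay and not a number. In this assay compound 2 gives > 10000 nM, again a limit of the assay rather than a measured number. Among the compounds with values here, compound 2 therefore stands where every value so far stands, at the limit of > 10000 nM in this assay, at which 2 of the 2 values shown sit, so no ranking of the two measured compounds is possible and no compound can be called stronger or weaker than the other. Compound 3 differs from compound 2 in one place: hydrogen in place of bromo on an aromatic carbon. Within the data shown here, no step between two measured compounds exists to calibrate this change, and with both measured values sitting at the limit there is no slope to extend. The working expectation is therefore no step beyond the usual scatter, the expected shift being a step that the limit leaves unreadable from compound 2 to compound 3. Compound 3 is estimated at 12000 nM, with a range from 5000 nM to 40000 nM, and most likely another limit rather than a number.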

Compound 3, half-maximal inhibitory concentration: > 10000 nM
Compound 3 gave a limit, no number; the forecaster's own chance of this, stated with the estimate: 80%; the middle value does not contradict the limit.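

Compound 2 and compound 3 both give only a limit in this assay, so no step can be read for hydrogen in place of bromo on an aromatic carbon: the limit of > 10000 nM in this assay, at which 3 of the 3 values shown sit.

The compounds shown leave open how bromo and hydrogen at this place compare, and which change to the shared core would give a measurable value in this assay.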